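A few compounds are considered here, and "the series" means these few. Any claim that something is new, unique, unknown or untested is made for them only; others in the source may bear on it.

Compound 1 `CCN(CC)CN1C(=O)/C(=N\c2nc3ccc(C)cc3s2)c2ccccc21` and compound 2 `Cc1ccc2nc(/N=C3\C(=O)N(CN(C)C)c4ccccc43)sc2c1` share one core and have both been tested in a functional assay on MDA-MB-231 cells (Homo sapiens) for cytotoxicity, read by sulforhodamine B assay, with a stated time of 48 h; a higher number here means a weaker inhibitor of growth, a lower number a stronger inhibitor of growth. In this assay compound 1 gives 32700 nM, which is the higher of the two numbers shown, while compound 2 gives 19200 nM; the single measured step, a 1.7-fold lower number from compound 1 to compound 2 (0.23 log units; within the scatter), stays within the scatter. Compound 3 `CCN(CC)CN1C(=O)/C(=N\c2nc3ccc(C)cc3s2)c2c(Cl)cccc21` has not yet been measured. It differs from compound 1 by chloro in place of hydrogen on an aromatic carbon. Among the measured compounds shown here, no measured step touches this aromatic position: the one step known, a 1.7-fold lower number from compound 1 to compound 2 (0.23 log units; within the scatter), concerns a saturated chain carbon and offers no guide to direction. With nothing to point either way, no move beyond the scatter is expected in this assay. The estimate for compound 3 in this assay is therefore 26000 nM, with a range from 9000 nM to 80000 nM. The expected step of a 1.3-fold lower number from compound 1 to compound 3 (0.10 log units; within the scatter) is accordingly small.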

Compound 3, concentration for 50% growth inhibition: 20400 nM
Estimate against measurement, compound 3: 1.3-fold (0.11 log units) above, within the range that was stated.
By their numbers in this assay, from the lowest: compounds 2, 3 and 1 (each within the scatter of the next).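

Among the compounds shown here, this is the first reading at this position: in this assay, chloro in place of hydrogen on an aromatic carbon of the six-membered ring of carbon only gives a 1.6-fold lower number from compound 1 to compound 3 (0.20 log units; within the scatter), a step that stays within the scatter. The position therefore accepts a single chlorine atom on the core of compound 1 without a clear shift in growth inhibition, so this change neither clearly helps nor clearly harms. No separate measurement bears on what the chloro does at this carbon.

Going by these compounds, whether a larger or different group, such as methoxy or an amine, would be accepted here remains open. So does whether chloro would behave the same way on the other carbons of this ring, or alongside the dimethylamino group of compound 2.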